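Hydroxy in Place of Methoxy: What Compound 3 Might Show

A few compounds are considered here, and "the series" means these few. Any claim that something is new, unique, unknown or untested is made for them only; others in the source may bear on it.

Of the compounds shown here, two have been measured in a functional assay on UO-31 cells (Homo sapiens) for inhibition, read by sulforhodamine B assay, with a stated time of 48 h; on this read-out lower numbers stand for stronger inhibition of growth and higher numbers for weaker inhibition of growth. Compound 1 `Cc1cc(O)cc(-c2nn(CC#N)cc2-c2ccnc(-c3ccc(Oc4ccccc4)cc3)c2)c1` gives 2180 nM in this assay. Compound 2 `COc1cc(C)cc(-c2nn(CC#N)cc2-c2ccnc(-c3ccc(N(C)C)cc3)c2)c1` gives 619 nM in this assay, the lower of the two numbers; compound 1 stands beyond the scatter above it. Compound 3 `Cc1cc(O)cc(-c2nn(CC#N)cc2-c2ccnc(-c3ccc(N(C)C)cc3)c2)c1` has not yet been measured. It differs from compound 2 in one place: hydrogen in place of methyl on an oxygen on an aromatic ring, which is the methoxy group becoming hydroxy, so that 3-methoxy-5-methylphenyl becomes 3-hydroxy-5-methylphenyl. Among the compounds with values here, no measured pair shows this change on its own. Compound 1 also carries the hydroxy, but it differs from compound 2 at the other end as well, so its value cannot be read as this step. The step is expected to be small, with no direction beyond the scatter, so that compound 3 is expected to give 700 nM in this assay, between 250 nM and 2000 nM, a step of a 1.1-fold higher number from compound 2 to compound 3 (0.05 log units; within the scatter) from compound 2.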

Compound 3, concentration for 50% growth inhibition: 3230 nM
For compound 3 the middle estimate is 4.6-fold (0.66 log units) below the measured one, and the stated range ends below it.
By their numbers in this assay, from the lowest: compound 2; then compounds 1 and 3 (each within the scatter of the next).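

At this position the methoxy is not interchangeable with hydroxy: in this assay, hydrogen in place of methyl on the oxygen gives a 5.2-fold higher number from compound 2 to compound 3 (0.72 log units; beyond the scatter) and so costs measurable growth inhibition on this core, which the first two compounds, differing at both ends, could not separate. With the hydroxy held in place, dimethylamino in place of phenoxy gives a 1.5-fold higher number from compound 1 to compound 3 (0.17 log units; within the scatter) and stays within the scatter, so in this hydroxy pair the exchange at the other end shows no measurable difference. Nothing measured here gives a reason for the loss on going from methoxy to hydroxy.

As far as these compounds go, whether the methoxy step would be the same size with phenoxy at the other end remains open. Also open, from the compounds shown here alone, is how groups such as ethoxy, an amine or a fluorine atom would read at this position.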